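Chain Length and Antiproliferative Potency in Aminooxolane Analogues

The source may report more compounds than this note shows. Statements on the series, on what has been measured and on what is new or still open speak of the compounds shown alone.

Measured so far:
compound 1, `CCCCCCCCCCCCNC[C@@H]1OC[C@H](N)[C@H]1O` — 2380 nM
compound 2, `CCCCCCCCNC[C@@H]1OC[C@H](N)[C@@H]1O` — 13800 nM
compound 3, `CCCCCCCCCCNC[C@@H]1OC[C@H](N)[C@H]1O` — limit, > 128000 nM

In a functional assay on PC-3 cells (Homo sapiens) for antiproliferative activity, read by MTT assay, with a stated time of 72 h (on this read-out lower numbers stand for stronger inhibition and higher numbers for weaker inhibition), compound 1 gives 2380 nM and compound 2 gives 13800 nM, the highest of the two numbers shown. For compound 3 only a limit of the assay is known, > 128000 nM. Among the compounds with values here, the one step between measured compounds, an at least 53-fold higher number from compound 1 to compound 3 (1.73 log units; beyond the scatter), shows that shortening the chain by two carbons costs a great deal, although the reading at the limit of > 128000 nM in this assay, at which 1 of the 3 values shown sits, means its true size is unknown.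

Compound 4, `CCCCCCCCCCCNC[C@@H]1OC[C@H](N)[C@@H]1O`, arises from compound 2 by propyl in place of hydrogen on a saturated chain carbon, eight bonds along the chain from an amine nitrogen. Within the data shown here, only the step from compound 1 to compound 3 bears on a chain-length change, and it points toward longer chains giving lower numbers in this assay. Compound 4 is therefore expected to give a lower number than compound 2, with a 2.8-fold lower number from compound 2 to compound 4 (0.44 log units; beyond the scatter), though compound 2 itself does not follow a simple chain-length order against compound 3. The estimate for compound 4 is 5000 nM, in the range 1000 nM to 50000 nM.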

Compound 4, half-maximal inhibitory concentration: 3330 nM
Estimate against measurement, compound 4: 1.5-fold (0.18 log units) above; measured number inside the range.
By their numbers in this assay, from the lowest: compounds 1 and 4 (each within the scatter of the next); then compound 2. At a limit, above all of these: compound 3.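

The propyl in place of hydrogen gives a 4.1-fold lower number from compound 2 to compound 4 (0.62 log units; beyond the scatter) in this assay, so the gain from lengthening the chain at this place, eight bonds along the chain from an amine nitrogen, now has a readable size, with a real number at both ends. The earlier chain step ended at compound 3, whose reading is only a limit: the limit of > 128000 nM in this assay, at which 1 of the 4 values shown sits. Compounds 2 and 4 carry a different spatial form of the core from compounds 1 and 3, yet in both pairs the longer chain goes with the lower number.

Whether this continues with a chain longer than any shown, or with a chain ending in a phenyl ring or a carboxylic acid, stays open. As far as these compounds go, how the two spatial forms of the core compare at one and the same chain length also stays open.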